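This account rests on a few compounds, and the source may have more. Where it says the series, first, only, none or still open, it means among the compounds named here.

Going by the values given here, compound 3 `O=S(=O)(NCCCNCc1ccc(Br)cc1)c1cc(C(F)(F)F)cc(C(F)(F)F)c1` gives the lowest number of the three compounds measured so far, 2800 nM in a functional assay on ASPC1 cells (Homo sapiens) for inhibition, read by MTT assay, with a stated time of 72 h; a lower number here means a stronger inhibitor of growth, a higher number a weaker inhibitor of growth; compound 2 `O=S(=O)(NCCCNCc1ccccc1)c1cc(C(F)(F)F)cc(C(F)(F)F)c1` gives 13000 nM and compound 1 `CN(CCCNS(=O)(=O)c1cc(C(F)(F)F)cc(C(F)(F)F)c1)Cc1ccccc1` gives 51000 nM. Compound 4 `COc1ccccc1CNCCCNS(=O)(=O)c1cc(C(F)(F)F)cc(C(F)(F)F)c1` differs from compound 3 in one place: 2-methoxyphenyl in place of 4-bromophenyl on a saturated chain carbon bound to an amine nitrogen. Among the compounds with values here, of the measured steps, only the one from compound 2 to compound 3 bears on this change, since it too alters the aromatic ring of the benzyl group: a 4.6-fold lower number from compound 2 to compound 3 (0.67 log units; beyond the scatter). Within the data shown here, no measured step involves a methoxy group, so what the entering group contributes is unknown. The bromo leaves here, so a number nearer that of compound 2 is expected. Compound 4 is estimated at 8000 nM, within 2500 nM to 25000 nM, which means a step of a 2.9-fold higher number from compound 3 to compound 4 (0.46 log units; beyond the scatter).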

Compound 4, concentration for 50% growth inhibition: 4600 nM
The estimate for compound 4 lay 1.7-fold (0.24 log units) above the measured number, within the range that was stated.
By their numbers in this assay, from the lowest: compounds 3 and 4 (each within the scatter of the next); then compound 2; then compound 1.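

In this assay, the exchange of 4-bromophenyl for 2-methoxyphenyl on a saturated chain carbon bound to an amine nitrogen leaves the two compounds within the scatter (a 1.6-fold higher number from compound 3 to compound 4 (0.22 log units; within the scatter)), so this change does not separate them. Adding a methoxy group to the aromatic ring also gives a lower number (a 2.8-fold lower number from compound 2 to compound 4 (0.45 log units; beyond the scatter)), so bromo is not the only substituent shown to do so, and the widest step to the new compound starts from the benzyl(methyl)amino compound (an 11-fold lower number from compound 1 to compound 4 (1.04 log units; beyond the scatter)). No evidence is at hand on what lies behind these steps. As far as these compounds go, whether a nitrile or a carboxylic acid on the aromatic ring would give a similar number stays open. So does the effect of a longer chain.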